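Ring amine capping in the CXCR3 antagonist series

The compounds below may be only part of what the source reports. "The series", "measured", "known", "first", "only" and "open" are said of these compounds alone.

Measured so far:
compound 1 `NC(=O)N1CCCC(c2ccccc2)(C2CCN(Cc3ccc(Br)cc3)CC2)C1` 250 nM
compound 2 `NS(=O)(=O)N1CCCC(c2ccccc2)(C2CCN(Cc3ccc(Br)cc3)CC2)C1` 210 nM

In a functional assay on CHO cells for antagonist activity at C-X-C chemokine receptor type 3 (Homo sapiens), read by GTPgammaS binding, with a stated time of 30 min (on this read-out lower numbers stand for stronger inhibition and higher numbers for weaker inhibition), compound 2 gives 210 nM, the lowest of the two numbers shown; the nearest is compound 1 with 250 nM, and the two lie within the scatter of each other. Among the measured compounds shown here, the only measured step, a 1.2-fold lower number from compound 1 to compound 2 (0.08 log units; within the scatter), exchanges one capping group on the ring amine nitrogen for another and moves the number within the scatter.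

Compound 3 `Brc1ccc(CN2CCC(C3(c4ccccc4)CCCNC3)CC2)cc1` removes the cap altogether: hydrogen in place of sulfamoyl on an amine nitrogen in a ring. For the measured compounds named here, no measured step removes the group from that nitrogen, so the step from compound 1 to compound 2 bears on it only in showing that the read-out tolerated an exchange at this position. Loss of the cap is a larger change than that exchange and could move the number in either direction; a moderate rise beyond the scatter is expected as the more likely outcome, with considerable uncertainty. For compound 3 the estimate in this assay is 500 nM (range 150 nM to 2000 nM), which corresponds to an expected step of a 2.4-fold higher number from compound 2 to compound 3 (0.38 log units; beyond the scatter).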

Compound 3, half-maximal inhibitory concentration: > 10000 nM
Compound 3: no number, only a limit; the forecaster's own chance of this, stated with the estimate: 5%; middle value at least 20-fold (1.30 log units) away from the limit.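

In this assay compound 3 gives > 10000 nM, which is a limit of the assay and not a number. Hydrogen on the ring amine nitrogen gives an at least 47-fold higher number from compound 2 to compound 3 (1.67 log units; beyond the scatter), and the same change from the other cap gives an at least 40-fold higher number from compound 1 to compound 3 (1.60 log units; beyond the scatter), both large and beyond the scatter. The two capped compounds lie within the scatter of each other, so this nitrogen tolerates an exchange between carbamoyl and sulfamoyl but not the loss of the cap, and the full size of that loss stays unread past the limit.

The compounds shown leave open whether any group on this nitrogen restores the number or only caps of these two kinds do. A methyl, an acetyl or a methanesulfonyl group at the same nitrogen would separate those readings.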